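This account rests on a few compounds, and the source may have more. Where it says the series, first, only, none or still open, it means among the compounds named here.

Measured in a functional assay on CHO cells for antagonist activity at corticotropin-releasing factor receptor 1 (Homo sapiens), read by cAMP accumulation; on this read-out lower numbers stand for stronger inhibition and higher numbers for weaker inhibition:
- compound 1 `CCCNCc1nnc(Nc2nc(C)nc3c2c(C)nn3-c2ccc(OC)cc2C)o1` gives 996 nM
- compound 2 `CCCNCc1noc(Nc2nc(C)nc3c2c(C)nn3-c2ccc(OC)cc2C)n1` gives 84 nM
- compound 3 `CC[C@@H](COC)Nc1nc(C)nc2c1c(C)nn2-c1ccc(OC)cc1C` gives 135 nM

Compound 3 stands second highest of the three numbers. Its nearest neighbour is compound 2, with a 1.6-fold higher number from compound 2 to compound 3 (0.21 log units; within the scatter); its furthest is compound 1, with a 7.4-fold lower number from compound 1 to compound 3 (0.87 log units; beyond the scatter).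

Compound 4 `CCC[C@@H](CO)Nc1nc(C)nc2c1c(C)nn2-c1ccc(OC)cc1C` differs from compound 3 in one place: 1-(hydroxymethyl)butyl in place of 1-(methoxymethyl)propyl on a nitrogen on an aromatic ring. For the measured compounds named here, none of the measured steps bears on this change. The steps of a 12-fold lower number from compound 1 to compound 2 (1.07 log units; beyond the scatter) and a 7.4-fold lower number from compound 1 to compound 3 (0.87 log units; beyond the scatter) each replace the whole group on the nitrogen with a different kind of group, and the step from compound 2 to compound 3 sits within the scatter. There is therefore no basis for expecting a step beyond the scatter, and compound 4 is expected to show a 1.1-fold higher number from compound 3 to compound 4 (0.05 log units; within the scatter). Compound 4 is estimated at 150 nM, within a range of 50 nM to 450 nM.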

Compound 4, inhibition constant: 574 nM
Compound 4: the middle estimate sits 3.8-fold (0.58 log units) below what was measured; the whole stated range lies below it.
By their numbers in this assay, from the lowest: compounds 2 and 3 (each within the scatter of the next); then compounds 4 and 1 (each within the scatter of the next).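

In this assay, 1-(hydroxymethyl)butyl in place of 1-(methoxymethyl)propyl on this nitrogen gives a 4.3-fold higher number from compound 3 to compound 4 (0.63 log units; beyond the scatter), so two groups of equal heavy-atom count are not interchangeable here. Compound 4 also falls apart from compound 2, with a 6.8-fold higher number from compound 2 to compound 4 (0.83 log units; beyond the scatter), whereas a 1.7-fold lower number from compound 1 to compound 4 (0.24 log units; within the scatter) leaves it within the scatter of compound 1. No evidence is available that accounts for the step.

The change alters the chain and its methoxy or hydroxy end together, so the compounds shown leave open which of these carries the step. The 1-(methoxymethyl)butyl and 1-(hydroxymethyl)propyl groups would separate the two.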